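Replacing the phenylsulfamoyl group on the shared core

The source may hold more compounds than are shown below. What is called first, only, known or untested is meant among the compounds shown, and "the series" means these compounds.

The series shares the core shown in compound 1 `CC#C[C@H]1CN(S(=O)(=O)c2ccc(N)nc2)CCN1c1ccc(S(=O)(=O)NC)cn1`, which in an assay on cells (Hepatocyte) for inhibition of glucokinase regulatory protein (Mus musculus), with stated times of 20 min and 40 min (on this read-out lower numbers stand for an effect already at smaller amounts and higher numbers for an effect only at larger amounts of compound), gives 381 nM. Compound 2 `CC#C[C@H]1CN(S(=O)(=O)c2ccc(N)nc2)CCN1c1ncc(C(C)(O)C(F)(F)F)s1` carries a different aromatic ring on the same core; in this assay compound 2 is reported only as a limit of the assay, > 12500 nM. Compound 3 `CC#C[C@H]1CN(S(=O)(=O)c2ccc(N)nc2)CCN1c1ccc(S(=O)(=O)Nc2ccccc2)cc1` bears a phenylsulfamoyl group on a six-membered aromatic ring of carbon only, and in this assay compound 3 likewise returns only a limit of the assay, > 12500 nM. Compound 3 thus stands at the limit of > 12500 nM in this assay, at which 2 of the 3 values shown sit, and no number for it is known.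

Compound 4 `CC#C[C@H]1CN(S(=O)(=O)c2ccc(N)nc2)CCN1c1ccc(S(=N)(=O)C2CC2)cc1` differs from compound 3 in one place: a group of 6 heavy atoms (3 carbon, 1 nitrogen, 1 oxygen, 1 sulfur; one three-membered non-aromatic ring of carbon only) in place of a group of 10 heavy atoms (6 carbon, 1 nitrogen, 2 oxygen, 1 sulfur; one six-membered aromatic ring of carbon only), on an aromatic carbon. Going by the values given here, the entering group is the smaller of the two, and the one measured number in the set, that of compound 1 with its methylsulfamoyl group, is 381 nM. Among the compounds with values here, no measured step in this set connects such a change to a number, so the expectation rests on the size of the group alone. Compound 4 is expected to move toward smaller amounts, by a step of an at least 5.0-fold lower number from compound 3 to compound 4 (0.69 log units; beyond the scatter), though a second limit cannot be ruled out. The estimate for compound 4 in this assay is 2500 nM, within 400 nM to 12500 nM.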

Compound 4, half-maximal effective concentration: 208 nM
For compound 4 the middle estimate is 12-fold (1.08 log units) above the measured one; the whole stated range lies above it.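

At the place para to a large group, on an aromatic carbon of a six-membered aromatic ring of carbon only, the core without a ring nitrogen can carry a measured value in this assay: exchanging the phenylsulfamoyl group for the smaller group with its three-membered ring gives an at least 60-fold lower number from compound 3 to compound 4 (1.77 log units; beyond the scatter). The two groups have the same counts of hydrogen-bond donors, hydrogen-bond acceptors and double bonds outside aromatic rings, so the step goes with a change in heavy atoms and ring, not with a change in those counts. The true size of the step is unknown, because its starting point is a limit of the assay and not a number: the limit of > 12500 nM in this assay, at which 2 of the 4 values shown sit.

The compounds shown do not separate the loss of the six-membered aromatic ring from the other changes at the sulfur group, as this single step changes both together. From the compounds shown here alone, what a carboxylic acid, an amine or a simple methylsulfonyl group would give at this place on the same core remains open.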